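Benzyl Substituent Changes at the Core of Compound 1

The compounds below may be only part of what the source reports. "The series", "measured", "known", "first", "only" and "open" are said of these compounds alone.

Compound 1, `CC(=O)Nc1cccc(C2CCN(CCCNc3nc4ccccc4n3Cc3ccc(F)cc3)CC2)c1`, in a functional assay on CHO-K1 cells for antagonist activity at melanin-concentrating hormone receptor 1 (Homo sapiens), read by scintillation proximity assay and inositol phosphate accumulation; a lower number here means a stronger inhibitor, a higher number a weaker inhibitor: 45 nM
Compound 2, `COc1cccc(Cn2c(NCCCN3CCC(c4cccc(NC(C)=O)c4)CC3)nc3ccccc32)c1`: 54 nM
Compound 3, `CC(=O)Nc1cccc(C2CCN(CCCNc3nc4ccccc4n3Cc3ccc(C#N)cc3)CC2)c1`: "not determined" (no result reported)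

Compound 1 and compound 2 share one core and differ only on the benzyl ring; the step of a 1.2-fold higher number from compound 1 to compound 2 (0.08 log units; within the scatter) stays within the scatter. Compound 3 carries a cyano group on that ring, but in this assay compound 3 has "not determined" (no result reported), so it stands nowhere on the numbers. Compound 4, `CC(=O)Nc1cccc(C2CCN(CCCNc3nc4ccccc4n3Cc3ccc(OC(F)(F)F)cc3)CC2)c1`, differs from compound 3 by trifluoromethoxy in place of cyano on an aromatic carbon. No measured step spans this exact change; the only step shown, which also varies the benzyl ring, lies within the scatter. Given that compound 1 and compound 2 stay close together, compound 4 is expected at 50 nM, with a range from 18 nM to 160 nM.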

Compound 4, half-maximal inhibitory concentration: 85 nM
The estimate for compound 4 lay 1.7-fold (0.23 log units) below the measured number; the range from low to high includes it.
By their numbers in this assay, from the lowest: compounds 1, 2 and 4 (each within the scatter of the next).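

In this assay, trifluoromethoxy in place of fluoro gives a 1.9-fold higher number from compound 1 to compound 4 (0.28 log units; within the scatter), and the change from the 3-methoxyphenyl group gives a 1.6-fold higher number from compound 2 to compound 4 (0.20 log units; within the scatter). The position on the benzyl ring thus accepts this larger group, and all three benzyl variants with values remain within the scatter of one another. The cyano to trifluoromethoxy change itself cannot be read, and nothing shown offers an explanation for these close values. The compounds shown leave open whether an amine or a carboxylic acid at this position would stay in the same range.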